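The compounds below may be only part of what the source reports. "The series", "measured", "known", "first", "only" and "open" are said of these compounds alone.

Measured so far:
compound 1 `C[C@H](Oc1cc2cc(C(N)=O)ccc2nc1N)c1cc2c(cnn2CCO)cc1-n1cccn1` — 4 uL/min
compound 2 `C[C@H](Oc1cc2ccccc2nc1N)c1cc(F)ccc1-n1cccn1` — "not determined" (no result reported)

Among the measured compounds shown here, compound 1 carries the only number in the set; in an ADME assay on cells (Hepatocyte, Homo sapiens) for metabolic stability (a higher number here means faster removal of the compound, a lower number slower removal), compound 1 gives 4 uL/min, and compound 2 contributes nothing to compare it with. Compound 3 `C[C@H](Oc1cc2cc(C(N)=O)ccc2nc1N)c1cc2[nH]ncc2cc1-n1cccn1` is not yet measured. It differs from compound 1 by hydrogen in place of 2-hydroxyethyl on an aromatic nitrogen. For the measured compounds named here, no step between measured compounds is available to calibrate this change, so the expectation rests on compound 1 alone. The step is expected to stay within the usual scatter, if anything slightly downward. Compound 3 is estimated at 4 uL/min in this assay, range 2 uL/min to 9 uL/min, meaning a step of no change at the digits printed from compound 1 to compound 3 (within the scatter).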

Compound 3, intrinsic clearance in a liver preparation (reported as CLH), per the amount of preparation that the assay uses in the Hepatocyte assay: < 3 uL/min
Compound 3 was reported as a limit (the forecaster's own chance of this, stated with the estimate: 15%); middle value at least 1.3-fold (0.12 log units) away from the limit.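

In the Hepatocyte assay, hydrogen in place of 2-hydroxyethyl on the aromatic nitrogen gives an at least 1.3-fold lower number from compound 1 to compound 3 (0.12 log units; that floor lies within the scatter). The reading for compound 3 there is a limit and not a number. In a physicochemical assay for lipophilicity, using the shake flask method (on this read-out lower numbers stand for lower lipophilicity and higher numbers for higher lipophilicity), compound 1 gives 2.1 and compound 3 gives 2.7, a gap beyond the scatter, so this position can lose the 2-hydroxyethyl with a clear shift on that read-out and no rise in the Hepatocyte assay.

From the compounds shown here alone, how a methyl group, a longer chain or a carboxylic acid on the same nitrogen would read stays open. Going by these compounds, the true size of the step in the Hepatocyte assay also stays open.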